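From 2-fluorophenyl to 4-fluorophenyl on a sulfonyl sulfur

The source may report more compounds than this note shows. Statements on the series, on what has been measured and on what is new or still open speak of the compounds shown alone.

Of the compounds shown here, two have been read in a functional assay on HEK293 cells (Homo sapiens) for cytotoxicity; a lower number here means that less compound is tolerated, a higher number that more compound is tolerated. Compound 1 (`COc1ccc([C@H]2CC(=O)N(c3cccc(NS(=O)(=O)c4cccc(OC(F)(F)F)c4)c3)C2)cc1OC1CCCC1`) gives > 10000 nM as a limit of the assay, not a number. Compound 2 (`COc1ccc([C@H]2CC(=O)N(c3cccc(NS(=O)(=O)c4ccccc4F)c3)C2)cc1OC1CCCC1`) gives > 10000 nM as a limit too, so its true position is not known. Both readings sit at the same ceiling (the limit of > 10000 nM in this assay, at which 2 of the 2 values shown sit).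

Compound 3 (`COc1ccc([C@H]2CC(=O)N(c3cccc(NS(=O)(=O)c4ccc(F)cc4)c3)C2)cc1OC1CCCC1`) has 4-fluorophenyl in place of 2-fluorophenyl on a sulfonyl sulfur. Going by the values given here, the only measured step bearing on this change is at the same attachment point (a step that the two limits leave unreadable from compound 1 to compound 2), and it has no readable size. It therefore offers no direction for the new change, though neither sulfonyl substituent in the measured pair brought a value under the limit.

No step beyond the scatter is expected in this assay, and another limit is the most likely report. The expected step is a step that the limit leaves unreadable from compound 2 to compound 3 and carries no firm direction. For compound 3 the estimated value is 15000 nM (range 8000 nM to 40000 nM).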

Compound 3, half-maximal cytotoxic concentration: > 10000 nM
Compound 3 was reported as a limit (the forecaster's own chance of this, stated with the estimate: 85%); the middle value is on the limit's open side.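

No step among compound 1, compound 2 and compound 3 can be read in this assay, as all three readings are limits of the assay, not numbers: the limit of > 10000 nM in this assay, at which 3 of the 3 values shown sit.

The compounds shown leave open where their true cytotoxic concentrations lie, and whether any aryl group on the sulfonyl sulfur of the shared core brings a reading under that limit.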